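A few compounds are considered here, and "the series" means these few. Any claim that something is new, unique, unknown or untested is made for them only; others in the source may bear on it.

In a functional assay (a lower number here means a stronger inhibitor, a higher number a weaker inhibitor), compound 1 `CC(C)=CCOc1ccc2c(c1)OC(c1ccccc1)CC2=O` gives 6070 nM and compound 2 `CC(C)=CCOc1cc(O)c2c(c1)OC(c1ccccc1)CC2=O` gives 7320 nM, so compound 2 stands level with compound 1 within the scatter. Compound 3 `CC(C)=CCOc1cc(O)c2c(c1)OC(c1ccccc1Cl)CC2=O` differs from compound 2 by chloro in place of hydrogen on an aromatic carbon, phenyl to 2-chlorophenyl (chloro in place of hydrogen on an aromatic carbon). Within the data shown here, the only measured step, a 1.2-fold higher number from compound 1 to compound 2 (0.08 log units; within the scatter), is small and concerns hydroxy, not chloro, so it offers no direct guide to this change. No step beyond the scatter in this assay is therefore expected, and no direction can be called. The expected step is a 1.2-fold lower number from compound 2 to compound 3 (0.09 log units; within the scatter). For compound 3 the estimate is 6000 nM, with an expected range of 2000 nM to 16000 nM.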

Compound 3, half-maximal inhibitory concentration: 4270 nM
The estimate for compound 3 lay 1.4-fold (0.15 log units) above the measured number; low and high end bracket the measured number.
By their numbers in this assay, from the lowest: compounds 3, 1 and 2 (each within the scatter of the next).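

In this assay, 2-chlorophenyl in place of phenyl gives a 1.7-fold lower number from compound 2 to compound 3 (0.23 log units; within the scatter), so the series accepts chloro on this aromatic carbon, ortho to a large group, without a step beyond the scatter. Among these compounds, this is the first measured change on the phenyl group, and like the hydroxy step it leaves the number within the scatter. No measurement available here bears on the reason for this result. Going by these compounds, whether a methoxy group or an amine on this ring would give a step beyond the scatter remains open. So does the effect of chloro elsewhere on the ring.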